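This account rests on a few compounds, and the source may have more. Where it says the series, first, only, none or still open, it means among the compounds named here.

Of the compounds shown here, three have so far been measured in an assay on Sf9 cells for inhibition of activin receptor type-1 (Homo sapiens), read by HTRF, with a stated time of 3 h, in the presence of a further agent that is not named here; a lower number here means a stronger inhibitor, a higher number a weaker inhibitor. Compound 1 `COC(=O)N1C[C@@H](C)N(c2ncc3[nH]nc(-c4ccc(N5CCN[C@H](C)C5)nc4)c3n2)[C@@H](C)C1` gives 0.85 nM, compound 2 `CCOC(=O)N1C[C@@H](C)N(c2ncc3[nH]nc(-c4ccc(N5CCN[C@H](C)C5)nc4)c3n2)[C@@H](C)C1` gives 4.9 nM, and compound 3 `C[C@@H]1CN(c2ccc(-c3n[nH]c4ccc(N5CCCCC5)nc34)cn2)CCN1` gives 95 nM. Compound 2 therefore holds the second highest of the three numbers: compound 1 stands below it, beyond the scatter, and compound 3 stands well above it, also beyond the scatter. Within the data shown here, the single one-point step among the measured compounds is a 5.8-fold higher number from compound 1 to compound 2 (0.76 log units; beyond the scatter), a modest weakening on lengthening the chain on the oxygen.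

Compound 4 `C[C@@H]1CN(c2ccc(-c3n[nH]c4cnc(N5[C@H](C)CN(C(=O)N(C)C)C[C@@H]5C)nc34)cn2)CCN1` has not yet been measured. It differs from compound 2 at the carbonyl carbon: dimethylamino in place of ethoxy on a carbonyl carbon. Cut one bond further out, ethoxycarbonyl becomes dimethylcarbamoyl. Among the measured compounds shown here, no measured pair shows this exchange. For the measured compounds named here, the only step that bears on it is the one already described, which shows that small changes at this end of the molecule move the number only modestly. Compound 3 carries no such group at all and differs from compound 2 in more than one place, so it offers no guide.

Compound 4 is therefore expected to stay close to compound 2, the estimated step being a 1.6-fold lower number from compound 2 to compound 4 (0.21 log units; within the scatter). Compound 4 is estimated at 3 nM, within a range from 1 nM to 12 nM.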

Compound 4, half-maximal inhibitory concentration: 6.4 nM
Beside the measured number, compound 4's estimate is 2.1-fold (0.33 log units) below it; the measured number falls inside the stated range.
By their numbers in this assay, from the lowest: compound 1; then compounds 2 and 4 (each within the scatter of the next); then compound 3.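

In this assay, a 1.3-fold higher number from compound 2 to compound 4 (0.12 log units; within the scatter), so on this carbonyl carbon, whose other neighbour is the amide-type nitrogen in a ring, dimethylamino and ethoxy cannot be told apart, although the atom bound to the carbonyl carbon is nitrogen in one and oxygen in the other. Against compound 1, the methoxy member of the set, the new result gives a 7.5-fold higher number from compound 1 to compound 4 (0.88 log units; beyond the scatter), a step of much the same kind as a 5.8-fold higher number from compound 1 to compound 2 (0.76 log units; beyond the scatter), so among these three compounds it is methoxy that stands apart, while ethoxy and dimethylamino lie together. No measurement is available that would explain why these groups rank as they do.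

The compounds shown leave open whether the low number of compound 1 is tied to methoxy itself or could also be reached with a methylamino group or a plain methyl on the same carbonyl carbon. They also leave open how a ring amine such as pyrrolidine, or a longer chain such as propoxy, would read at this place, and so whether the level shared by compound 2 and compound 4 extends to larger groups.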